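Swapping the Chain on the Ring Nitrogen

A few compounds are considered here, and "the series" means these few. Any claim that something is new, unique, unknown or untested is made for them only; others in the source may bear on it.

Compound 1 `COC(CCn1cnc2c(NCc3ccc(C(=O)Nc4ccccc4N)cc3)nc(Cl)nc21)OC`: 43.7%
Compound 2 `CCCCn1cnc2c(Nc3cccc(Cl)c3)nc(NCOCc3ccc(/C=C/C(=O)Nc4ccccc4N)cc3)nc21`: 25.7%

In a functional assay on NCI-H460 cells (Homo sapiens) for antiproliferative activity, read by CCK-8 assay, with a stated time of 72 h, tested at 2 uM (on this read-out higher numbers stand for a stronger effect at the one concentration tested and lower numbers for a weaker effect), compound 1 gives 43.7%, the higher of the two numbers measured. Compound 2 gives 25.7%, a number well beyond the usual scatter below it. Compound 3 `CCC(C)n1cnc2c(NCc3ccc(C(=O)Nc4ccccc4N)cc3)nc(Cl)nc21` has not yet been measured. It differs from compound 1 in one place (sec-butyl in place of 3,3-dimethoxypropyl on an aromatic nitrogen). With no comparable change among the measured compounds, the step is expected to be small and in no clear direction, so the estimated step of a number 3.7 percentage points lower from compound 1 to compound 3 (within the scatter) stays within the scatter. Compound 3 is therefore expected to give about 40%, with a range from 22% to 58%.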

Compound 3, a percentage reported as inhibition, at one concentration (the size of the read-out at that concentration, not a potency): 47.3%
Compound 3: middle estimate off by 7.3 percentage points, on the low side; low and high end bracket the measured number.
By their numbers in this assay, from the lowest: compound 2; then compounds 1 and 3 (each within the scatter of the next).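

Placing sec-butyl in place of 3,3-dimethoxypropyl on the aromatic nitrogen gives a number 3.6 percentage points higher from compound 1 to compound 3 (within the scatter) in this assay. At this position, then, the two oxygens and both hydrogen-bond acceptors of the chain can go without a change in the read-out that stands out from the scatter. No measurement here offers a reason for this result. Still open, on these data alone, is whether a chain ending in an amine or a carboxylic acid would give a similar number. As far as these compounds go, a much longer alkyl chain on this nitrogen remains equally open.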